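Swapping 4-bromophenyl for 3,4-dimethylphenyl on the amine nitrogen

The compounds below may be only part of what the source reports. "The series", "measured", "known", "first", "only" and "open" are said of these compounds alone.

Measured in a functional assay on ECa-109 cells for inhibition, with ECa-109 cell line (Homo sapiens) as the target, read by sulforhodamine B assay; a lower number here means a stronger inhibitor, a higher number a weaker inhibitor:
compound 1 `CCCc1ccc(NC2=CC(=O)c3nc4n(c3C2=O)[C@H]2OC[C@@H](O)[C@H]2OC4)cc1`: > 4000 nM (a limit)
compound 2 `O=C1C=C(N2CCC2)C(=O)c2c1nc1n2[C@H]2OC[C@@H](O)[C@H]2OC1`: > 16000 nM (a limit)
compound 3 `O=C1C=C(Nc2ccc(Br)cc2)C(=O)c2c1nc1n2[C@H]2OC[C@@H](O)[C@H]2OC1`: 2850 nM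

Among the measured compounds shown here, compound 3 holds the only actual number in this set, the other two values being limits. Compound 4 `Cc1ccc(NC2=CC(=O)c3nc4n(c3C2=O)[C@H]2OC[C@@H](O)[C@H]2OC4)cc1C` carries 3,4-dimethylphenyl in place of 4-bromophenyl on an amine nitrogen. The closest measured step, an at least 1.4-fold lower number from compound 1 to compound 3 (0.14 log units; that floor lies within the scatter), exchanges propyl for bromo on an aromatic carbon, and it points to a slightly higher number for compound 4, which also lacks the bromo. The other step, an at least 5.6-fold lower number from compound 2 to compound 3 (0.74 log units; beyond the scatter), is a change of a different kind and bears less on this one. The expected step is a 1.4-fold higher number from compound 3 to compound 4 (0.15 log units; within the scatter), probably no larger than the scatter. The estimate for compound 4 is 4000 nM, with an expected range of 1500 nM to 12000 nM.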

Compound 4, half-maximal inhibitory concentration: 2820 nM
For compound 4 the middle estimate is 1.4-fold (0.15 log units) above the measured one; low and high end bracket the measured number.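

In this assay, bromine is not required on this aryl group: 3,4-dimethylphenyl on the amine nitrogen gives a 1.0-fold lower number from compound 3 to compound 4 (0.00 log units; within the scatter). The arylamine also keeps its edge over azetidin-1-yl without bromine, with an at least 5.6-fold lower number from compound 2 to compound 4 (0.75 log units; beyond the scatter), though this is only a floor: the limit of > 16000 nM in this assay, at which 1 of the 4 values shown sits. Replacing 4-propylphenyl gives an at least 1.4-fold lower number from compound 1 to compound 4 (0.15 log units; that floor lies within the scatter), which can be read only as a floor because one end is a limit: the limit of > 4000 nM in this assay, at which 1 of the 4 values shown sits. The compounds shown leave open whether a carboxylic acid or a methoxy group on the phenyl ring would move the number in this assay.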